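One Methoxy Fewer on the Shared Core

This account rests on a few compounds, and the source may have more. Where it says the series, first, only, none or still open, it means among the compounds named here.

Two compounds set the reference. Among the measured compounds shown here, compound 1 `Cc1ccc(Nc2nnc(Nc3nc(-c4ccc(Cl)cc4)cs3)s2)cc1` and compound 2 `COc1ccccc1Nc1nnc(Nc2nc(-c3ccc(Br)cc3)cs2)s1` share a core and differ in more than one place, so no single step between them is defined. In a functional assay on the whole organism (strain albino) with Mus musculus as the target, in the maximal electroshock model, with a stated time of 0.5 h (on this read-out lower numbers stand for an effect already at smaller amounts and higher numbers for an effect only at larger amounts of compound), compound 1 gives 300 mg/kg, and in this assay compound 2 gives 300 mg/kg. Compound 2 therefore stands level with compound 1 at the digits shown, within the usual scatter, and nothing on this read-out separates the two.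

Compound 3 `Brc1ccc(-c2csc(Nc3nnc(Nc4ccccc4)s3)n2)cc1` has not yet been tested. It differs from compound 2 in one place: hydrogen in place of methoxy on an aromatic carbon. The methoxy leaves and hydrogen enters on an aromatic carbon of a six-membered aromatic ring of carbon only, ortho to a large group; cut one bond further out, the change reads 2-methoxyphenyl to phenyl.

For the measured compounds named here, no measured pair isolates a single change, so no step size is known from the data. Going by the values given here, the two values show only that compounds differing in several places gave the same reading. Compound 3 is expected to stay close to compound 2, with no change at the digits printed from compound 2 to compound 3 (within the scatter) estimated as no change beyond the scatter. The estimate for compound 3 in this assay is 300 mg/kg, with a range from 150 mg/kg to 600 mg/kg.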

Compound 3, minimum effective dose: 300 mg/kg
Beside the measured number, compound 3's estimate shows no gap at the digits printed, and the stated range covers the measured number.
By their numbers in this assay, from the lowest: compounds 1, 2 and 3 (each within the scatter of the next).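

Among the compounds shown here, compound 2 and compound 3 form the first pair here that differ in one place, so a single change can now be read on its own: hydrogen in place of methoxy on an aromatic carbon, ortho to a large group, gives no change at the digits printed from compound 2 to compound 3 (within the scatter) in this assay. At this position, then, going from 2-methoxyphenyl to phenyl leaves the reading on the core of compound 2 unmoved, and removing the methoxy, with its two heavy atoms and one hydrogen-bond acceptor, does not separate the two compounds on this read-out. Nothing offered here gives a reason for this result.

The compounds shown leave open whether this aromatic carbon would read the same with an amine, a carboxylic acid or a longer chain such as butoxy in place of the methoxy. As far as these compounds go, it also remains open whether the same change from 2-methoxyphenyl to phenyl would read alike elsewhere on the shared core, since this one step comes from a single pair.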